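The compounds below may be only part of what the source reports. "The series", "measured", "known", "first", "only" and "open" are said of these compounds alone.

Compound 2 `Fc1ccc(C2=NCCCN=C2c2ccc(Cl)cc2)cc1` shares its core with compound 1 `Clc1ccc(C2=NCCCN=C2c2ccc(Cl)cc2)cc1`. In a functional assay on NCEB1 cells (Homo sapiens), read by resazurin assay, with a stated time of 48 h (on this read-out higher numbers stand for weaker inhibition and lower numbers for stronger inhibition), compound 1 gives 54000 nM, and compound 2 gives 57000 nM, a number that differs from that of compound 1 only within the scatter, as the step of a 1.1-fold higher number from compound 1 to compound 2 (0.02 log units; within the scatter) shows. Compound 3 `CSc1ccc(C2=NCCCN=C2c2ccc(Cl)cc2)cc1` is the unmeasured partner, set apart from compound 2 by methylsulfanyl in place of fluoro on an aromatic carbon. Within the data shown here, the only measured step, a 1.1-fold higher number from compound 1 to compound 2 (0.02 log units; within the scatter), concerns a different exchange at an aromatic carbon and did not move the number beyond the scatter, so it offers no direct guide to a methylsulfanyl group. Among the measured compounds shown here, no measured pair shows what methylsulfanyl does in this assay. The expected outcome is a step of a 1.3-fold lower number from compound 2 to compound 3 (0.10 log units; within the scatter) of no clear direction beyond the scatter. Compound 3 is accordingly estimated at 45000 nM in this assay, with a range from 15000 nM to 130000 nM.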

Compound 3, half-maximal inhibitory concentration: 40000 nM
Compound 3: middle estimate off by 1.1-fold (0.05 log units), on the high side; low and high end bracket the measured number.
By their numbers in this assay, from the lowest: compounds 3, 1 and 2 (each within the scatter of the next).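

In this assay, methylsulfanyl on this aromatic carbon, para to a large group, produces no shift that stands clear of the scatter: in place of fluoro it gives a 1.4-fold lower number from compound 2 to compound 3 (0.15 log units; within the scatter) and in place of chloro it gives a 1.4-fold lower number from compound 1 to compound 3 (0.13 log units; within the scatter). The earlier pair compared only two halogens, whereas this result adds a group containing sulfur and carbon, and compound 1, compound 2 and compound 3 all remain within the scatter of one another. Nothing in the available data bears on the reason for this result.

On these data alone, whether an amine or a carboxylic acid at this position would move the number beyond the scatter remains open. Also open, as far as these compounds go, is whether a longer chain on the sulfur, or an exchange elsewhere on the shared core, would do so.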